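Furan-3-yl for thiophen-2-yl: working notes on the series

This account rests on a few compounds, and the source may have more. Where it says the series, first, only, none or still open, it means among the compounds named here.

compound 1 `CCN(c1ccc(C#N)c(Cl)c1)c1cc(-c2cccs2)ccc1C` reads "not determined" (no result reported)
compound 2 `Cc1noc(C)c1-c1cccc2c1CCCN2c1ccc(C#N)c(C(F)(F)F)c1` reads > 30000 nM

In a functional assay on VCaP cells (Homo sapiens) for antiproliferative activity, read by CCK-8 assay, with a stated time of 6 days (a higher number here means a weaker inhibitor, a lower number a stronger inhibitor), compound 1 has "not determined" (no result reported) as its entry, so it offers no number to start from. Compound 2 gives > 30000 nM as a limit of this assay and not a number. Going by the values given here, the series therefore holds no exact value so far.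

Compound 3 `CCN(c1ccc(C#N)c(Cl)c1)c1cc(-c2ccoc2)ccc1C` departs from compound 1 in one place, with furan-3-yl in place of thiophen-2-yl on an aromatic carbon is the whole of the change. Among the compounds with values here, no measured step bears on this swap, so in this assay no shift beyond the usual scatter is expected from it. For compound 3 an estimated 8000 nM is expected, with a range from 1500 nM to 30000 nM and a real chance that only a limit is reported.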

Compound 3, half-maximal inhibitory concentration: 4010 nM
Compound 3: middle estimate off by 2.0-fold (0.30 log units), on the high side; the measured number falls inside the stated range.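

No new step can be read between compound 1 and compound 3: compound 1 reads "not determined" (no result reported), while compound 3 gives 4010 nM. Going by these compounds, whether furan-3-yl and thiophen-2-yl differ on the shared core in this assay stays open.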